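Bromo in Place of Hydrogen on a Second Core

The compounds below may be only part of what the source reports. "The series", "measured", "known", "first", "only" and "open" are said of these compounds alone.

Compound 1 `c1cncc(N2CC[C@@H]3CN[C@@H]3C2)c1` and compound 2 `Brc1cncc(N2CC[C@@H]3CN[C@@H]3C2)c1` share one core and differ in a single place: bromo in place of hydrogen on an aromatic carbon. In a functional assay on HEK293 cells for agonist activity at Neuronal acetylcholine receptor; alpha4/beta2 (Homo sapiens), read by FLIPR (on this read-out higher numbers stand for an effect only at larger amounts of compound and lower numbers for an effect already at smaller amounts), compound 1 gives 330 nM, while compound 2 gives 1000 nM, so that a 3.0-fold higher number from compound 1 to compound 2 (0.48 log units; beyond the scatter). Compound 3 `COc1cncc(N2CC[C@H]3CN[C@H]3C2)c1` carries a different core; how its core differs from that of compound 1 is not broken down here. In this assay compound 3 gives 130 nM, the lowest of the three numbers. Compound 4 `COc1cc(N2CC[C@H]3CN[C@H]3C2)cnc1Br` has not yet been measured. Its difference from compound 3 is bromo in place of hydrogen on an aromatic carbon. Among the compounds with values here, this is the same kind of change as the one from compound 1 to compound 2, but not the same: here the bromo sits next to the ring nitrogen, ortho to a methoxy group and para to the group of 8 heavy atoms, whereas in compound 2 it sits two atoms from the ring nitrogen and meta to that group. For compound 4 the author expects a step of roughly the earlier size, a 3.1-fold higher number from compound 3 to compound 4 (0.49 log units; beyond the scatter), because the same change gave a 3.0-fold higher number from compound 1 to compound 2 (0.48 log units; beyond the scatter). Compound 4 is therefore estimated at 400 nM in this assay, with a likely range from 150 nM to 1200 nM.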

Compound 4, half-maximal effective concentration: 21 nM
Compound 4: the middle estimate sits 19-fold (1.28 log units) above what was measured; measured number below the stated range.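

In this assay the bromo for hydrogen change did not carry over from one core to the other, for here it gave a 6.2-fold lower number from compound 3 to compound 4 (0.79 log units; beyond the scatter). The direction of the step reversed, and the gap between the two steps exceeds what repeated measurement would account for: the same change on two cores in this assay, a 3.0-fold higher number (0.48 log units; beyond the scatter) from compound 1 to compound 2 and a 6.2-fold lower number (0.79 log units; beyond the scatter) from compound 3 to compound 4, 19-fold (1.27 log units) apart, beyond the scatter of two such steps

This does not show what separates the two results, since the pairs differ in their cores and also in where the bromo sits, next to the ring nitrogen and ortho to a methoxy group in compound 4 but not in compound 2, and two pairs cannot tell these apart.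

The compounds shown leave open whether bromo placed next to the ring nitrogen on the core of compound 1 would give a step like that of compound 4. They also leave open whether a chloro or a methyl in that same place, or an ethoxy in place of the methoxy group, would follow the bromo result.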